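Removing a Methyl From the Weakest Analogue of Three

The compounds below may be only part of what the source reports. "The series", "measured", "known", "first", "only" and "open" are said of these compounds alone.

Measured compounds in a functional assay on cells (Cancer cell lines, Homo sapiens) for cytotoxicity, with a stated time of 48 h; a lower number here means a stronger inhibitor of growth, a higher number a weaker inhibitor of growth:
compound 1 `COc1cc2c(/C=C3/C(=O)Nc4ccc(O)cc43)c(Cl)n(Cc3cc(OC)c(OC)c(OC)c3)c2cc1C` gives 2290 nM
compound 2 `COc1cc2c(/C=C3/C(=O)Nc4ccc(Cl)cc43)c(Cl)n(Cc3cc(OC)c(OC)c(OC)c3)c2cc1C` gives 1780 nM
compound 3 `COc1cc2c(cc1C)NC(=O)/C2=C/c1c(Cl)n(Cc2cc(OC)c(OC)c(OC)c2)c2cc(C)c(OC)cc12` gives 5500 nM

Compound 1 and compound 2 differ only in the group on one aromatic carbon, and the step of a 1.3-fold lower number from compound 1 to compound 2 (0.11 log units; within the scatter) stays within the scatter. Compound 3 stands apart: its number is the highest of the three, and its distance to compound 1 and to compound 2 is beyond the scatter in both cases, so compound 3 is the weakest inhibitor of growth among the measured compounds.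

Compound 4 `COc1ccc2c(c1)/C(=C\c1c(Cl)n(Cc3cc(OC)c(OC)c(OC)c3)c3cc(C)c(OC)cc13)C(=O)N2` is compound 3 with hydrogen in place of methyl on an aromatic carbon. Within the data shown here, the only measured step, from compound 1 to compound 2, exchanges one group for another on a different ring, and nothing among the measured compounds tests the loss of a methyl. Among the measured compounds shown here, no measured step therefore bears on this change. With no guidance in either direction, the step from compound 3 to compound 4 is expected to be no change at the digits printed from compound 3 to compound 4 (within the scatter), that is, none beyond the scatter. Compound 4 is accordingly estimated at 5500 nM, with a range from 2500 nM to 12000 nM.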

Compound 4, concentration for 50% growth inhibition: 14500 nM
For compound 4 the middle estimate is 2.6-fold (0.42 log units) below the measured one; measured number above the stated range.
By their numbers in this assay, from the lowest: compounds 2 and 1 (each within the scatter of the next); then compound 3; then compound 4.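

In this assay, the methyl on this aromatic carbon, ortho to a methoxy group, proves not to be neutral: hydrogen in its place gives a 2.6-fold higher number from compound 3 to compound 4 (0.42 log units; beyond the scatter), so in this pair the methyl goes with the stronger inhibition of growth. Compound 4 also shows that the other substituted carbon tolerates less than the hydroxy and chloro pair suggested, since methoxy in place of chloro gives an 8.1-fold higher number from compound 2 to compound 4 (0.91 log units; beyond the scatter) and methylating the hydroxy oxygen gives a 6.3-fold higher number from compound 1 to compound 4 (0.80 log units; beyond the scatter), which leaves compound 4 the weakest of the four. Nothing measured here explains either shift.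

Going by these compounds, whether an ethyl group or a chlorine at the methyl-bearing carbon would match or surpass methyl remains open. So does whether an amine at the other carbon would behave like hydroxy and chloro or like methoxy.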